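A few compounds are considered here, and "the series" means these few. Any claim that something is new, unique, unknown or untested is made for them only; others in the source may bear on it.

Compound 1 `COc1cc(/C=C2\CN(C)C/C(=C\c3ccc(Cl)cc3Cl)C2=O)cc(OC)c1` and compound 2 `COc1cc(/C=C2\CN(C)C/C(=C\c3ccc(Cl)c(Cl)c3)C2=O)cc(OC)c1` share one core and differ in a single ring. In a functional assay on THP-1 cells (Homo sapiens) for cytotoxicity, read by MTT assay, with a stated time of 24 h (on this read-out higher numbers stand for weaker inhibition and lower numbers for stronger inhibition), compound 1 gives 6070 nM, and compound 2 gives 3260 nM. The change between them is 3,4-dichlorophenyl in place of 2,4-dichlorophenyl on a double-bonded chain carbon bound to a double-bonded ring carbon, and it produced a 1.9-fold lower number from compound 1 to compound 2 (0.27 log units; within the scatter). Compound 3 `CN1C/C(=C\c2cccc([N+](=O)[O-])c2)C(=O)/C(=C/c2ccc(Cl)cc2Cl)C1` is built on a different core; how that core differs from the core of compound 1 is not broken down here. In this assay compound 3 gives 3560 nM. Compound 4 `CN1C/C(=C\c2cccc([N+](=O)[O-])c2)C(=O)/C(=C/c2ccc(Cl)c(Cl)c2)C1` stands to compound 3 as compound 2 stands to compound 1, through the same change, (3,4-dichlorophenyl in place of 2,4-dichlorophenyl on a double-bonded chain carbon bound to a double-bonded ring carbon), made at the same place. The expectation for compound 4 rests on the step of a 1.9-fold lower number from compound 1 to compound 2 (0.27 log units; within the scatter) staying within the scatter. For compound 4 the expected step is a 1.8-fold lower number from compound 3 to compound 4 (0.25 log units; within the scatter). Compound 4 is therefore estimated at 2000 nM, within a range from 800 nM to 5000 nM.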

Compound 4, half-maximal inhibitory concentration: 5020 nM
For compound 4 the middle estimate is 2.5-fold (0.40 log units) below the measured one; measured number above the stated range.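

On the core of compound 3, in this assay, the change gives a 1.4-fold higher number from compound 3 to compound 4 (0.15 log units; within the scatter). Set beside the same change on the core of compound 1, the two steps cannot be told apart: the same change on two cores in this assay, a 1.9-fold lower number (0.27 log units; within the scatter) from compound 1 to compound 2 and a 1.4-fold higher number (0.15 log units; within the scatter) from compound 3 to compound 4, 2.6-fold (0.42 log units) apart, within the scatter of two such steps. So in these two pairs, moving from 2,4-dichlorophenyl to 3,4-dichlorophenyl has no effect that stands clear of the scatter on either core, but this does not prove that the two cores respond alike, as a small real effect could lie hidden in that scatter.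

The compounds shown leave open whether a phenyl ring carrying an amine or a carboxylic acid instead of the two chlorines would give a step beyond the scatter. They also leave open whether either core would then respond as the other does.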